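Aryl change on the benzylic carbon of compound 3

The compounds below may be only part of what the source reports. "The series", "measured", "known", "first", "only" and "open" are said of these compounds alone.

Measured compounds:
- Compound 1, `O=C(O)C1CC1c1ccc(NCc2ccc(-c3ccccc3)cc2)cc1`: 80%
- Compound 2, `O=C(O)CCc1ccc(NCc2cccc(Br)c2)cc1`: 120%
- Compound 3, `O=C(O)CCc1ccc(NCc2ccc(Cl)s2)cc1`: 143%

Of the compounds shown here, three have been read in a functional assay on CHO cells for agonist activity at Free fatty acid receptor 1 (Homo sapiens), read by reporter gene assay; on this read-out higher numbers stand for larger maximal responses and lower numbers for smaller maximal responses. Compound 1 `O=C(O)C1CC1c1ccc(NCc2ccc(-c3ccccc3)cc2)cc1` gives 80% in this assay. Compound 2 `O=C(O)CCc1ccc(NCc2cccc(Br)c2)cc1` gives 120%, and compound 3 `O=C(O)CCc1ccc(NCc2ccc(Cl)s2)cc1` gives 143%. Compound 3 stands highest of the three numbers; its nearest neighbour is compound 2, whose number is lower by more than the usual scatter, and compound 1 lies furthest away, again beyond the scatter. Within the data shown here, none of these pairs differs in only one place, so no single step between measured compounds can be drawn.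

Compound 4 `O=C(O)CCc1ccc(NCc2ccccc2)cc1` has not yet been measured in this assay. It differs from compound 3 by phenyl in place of 5-chlorothiophen-2-yl on a saturated chain carbon bound to a nitrogen on an aromatic ring. Compound 2, which also carries a six-membered carbon ring on that carbon, gives a lower number than compound 3, so a downward step beyond the scatter is expected in this assay. The expected step is a number 43 percentage points lower from compound 3 to compound 4 (beyond the scatter). Compound 4 is therefore estimated at 100%, within a range from 70% to 130%.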

Compound 4, largest response reached (reported as percent of maximum), in percent of the reference or control that the assay uses: 144%
Compound 4: middle estimate off by 44 percentage points, on the low side; the measured number lies above the stated range.
By their numbers in this assay, from the lowest: compound 1; then compound 2; then compounds 3 and 4 (each within the scatter of the next).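

In this assay, phenyl in place of 5-chlorothiophen-2-yl on a saturated chain carbon bound to a nitrogen on an aromatic ring gives a number 1 percentage points higher from compound 3 to compound 4 (within the scatter), so these two aromatic rings cannot be told apart on this read-out, even though one is a five-membered ring with sulfur and chlorine and the other a six-membered ring of carbon only. Hydrogen in place of bromo on an aromatic carbon gives a number 24 percentage points higher from compound 2 to compound 4 (beyond the scatter), a modest step beyond the scatter, which shows that the lower number of compound 2 goes with its bromo and not with the six-membered carbon ring as such. No measurement shown here offers an explanation for either step.

Still open, as far as these compounds go, is whether a furan or pyridine ring at this carbon, or a chloro or methoxy group on the phenyl of compound 4, would keep the response at this level. Compound 1 differs from the other compounds in more than one place, so the contributions of its cyclopropane ring and its additional phenyl ring remain unseparated.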